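The source may hold more compounds than are shown below. What is called first, only, known or untested is meant among the compounds shown, and "the series" means these compounds.

Compound 1 `N[C@@H](CC1CCCCC1)CN(C(=O)[C@@H]1C[C@H]1c1ccccc1)c1ccc(-c2ccccc2)cc1`: 1.7 nM
Compound 2 `CC(C)C[C@H](N)CN(C(=O)[C@@H]1C[C@H]1c1ccccc1)c1ccc(C2=CCCC2)cc1`: 1200 nM

Among the measured compounds shown here, of these two, compound 2 has the highest number, and compound 1 has a far lower one; the two differ in more than one place, so no single step links them. Compound 3 `CC(C)C[C@H](N)CN(C(=O)[C@@H]1C[C@H]1c1ccccc1)c1ccc(-c2ccc(F)cc2)cc1` differs from compound 2 as follows: 4-fluorophenyl in place of cyclopent-1-en-1-yl on an aromatic carbon. In a functional assay for agonist activity at G protein-coupled receptor 88 (Homo sapiens), read by HTRF and cAMP accumulation (a lower number here means that less compound is needed, a higher number that more compound is needed for the effect), a move toward a lower number for compound 3 is expected, and the step of a 10-fold lower number from compound 2 to compound 3 (1.00 log units; beyond the scatter) is expected to be well beyond the scatter. Compound 3 is therefore estimated at 120 nM, within a range from 20 nM to 600 nM.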

Compound 3, half-maximal effective concentration: 900 nM
The estimate for compound 3 lay 7.5-fold (0.88 log units) below the measured number, outside the stated range (above it).
By their numbers in this assay, from the lowest: compound 1; then compounds 3 and 2 (each within the scatter of the next).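

In this assay, 4-fluorophenyl in place of cyclopent-1-en-1-yl gives a 1.3-fold lower number from compound 2 to compound 3 (0.12 log units; within the scatter) and so no real change. At this position, then, a six-membered aromatic ring with fluorine and a five-membered non-aromatic ring cannot be told apart by this read-out. Nothing available explains why the two groups match.

Among the compounds shown here, whether the fluorine matters remains open, as compound 3 has no plain phenyl counterpart with the same chain. Also open, from the compounds shown here alone, is how a morpholine ring, a carboxylic acid or a methoxy group would behave on this carbon.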